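The source may report more compounds than this note shows. Statements on the series, on what has been measured and on what is new or still open speak of the compounds shown alone.

Measured in an ADME assay on HepG2 cells (Homo sapiens) for cytotoxicity, read by neutral red uptake, with a stated time of 24 h; on this read-out lower numbers stand for stronger inhibition and higher numbers for weaker inhibition:
compound 1 `CCC(=O)Oc1c(C(C)C)cc2c3c1OC(=O)[C@@]31CCCC(C)(C)[C@@H]1CC2`: 196000 nM
compound 2 `CCCC(=O)Oc1c(C(C)C)cc2c3c1OC(=O)[C@@]31CCCC(C)(C)[C@@H]1CC2`: 56100 nM
compound 3 `CCCCCCCC/C=C/CCCCCCCC(=O)Oc1c(C(C)C)cc2c3c1OC(=O)[C@@]31CCCC(C)(C)[C@@H]1CC2`: > 1000000 nM (a limit of the assay, not a number)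

Compound 2 (56100 nM) holds the lower of the two true numbers. Compound 4 `CC(C)c1cc2c3c(c1OC(=O)CCCc1c[nH]c4ccccc14)OC(=O)[C@@]31CCCC(C)(C)[C@@H]1CC2` differs from it thus: 1H-indol-3-yl in place of hydrogen on a saturated chain carbon, three bonds along the chain from a carbonyl carbon (1H-indol-3-yl in place of hydrogen on a saturated chain carbon). Going by the values given here, the one measured step bearing on this is modest and also lies on the chain: a 3.5-fold lower number from compound 1 to compound 2 (0.54 log units; beyond the scatter) (methyl in place of hydrogen). On these data alone, the limit of compound 3 supplies no number, so the direction stays open. No step beyond the scatter is expected in this assay (estimated: a 1.2-fold higher number from compound 2 to compound 4 (0.10 log units; within the scatter)). The estimate for compound 4 is 70000 nM (expected range 20000 nM to 300000 nM).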

Compound 4, half-maximal inhibitory concentration: 120000 nM
Beside the measured number, compound 4's estimate is 1.7-fold (0.23 log units) below it; low and high end bracket the measured number.
By their numbers in this assay, from the lowest: compound 2; then compounds 4 and 1 (each within the scatter of the next). At a limit, above all of these: compound 3.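

On the saturated chain carbon three bonds along the chain from a carbonyl carbon, 1H-indol-3-yl in place of hydrogen adds 9 heavy atoms, yet in this assay the result is only a modest move (a 2.1-fold higher number from compound 2 to compound 4 (0.33 log units; beyond the scatter)). This runs in the opposite direction to the methyl step (a 3.5-fold lower number from compound 1 to compound 2 (0.54 log units; beyond the scatter)). The (1H-indol-3-yl)methyl change gives no separation (a 1.6-fold lower number from compound 1 to compound 4 (0.21 log units; within the scatter)).

On these data alone, the effect of an amine or a carboxylic acid on this chain remains open. Compound 3 gives a limit of the assay, not a number: the limit of > 1000000 nM in this assay, at which 1 of the 4 values shown sits.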